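Fluorine Pair in Place of Aniline on the Ketone Aryl

This account rests on a few compounds, and the source may have more. Where it says the series, first, only, none or still open, it means among the compounds named here.

Measured compounds:
compound 1, `COc1cc(-c2cc(/C=C/C(=O)c3ccc(N)cc3)[nH]n2)cc(OC)c1OC`: 7910 nM
compound 2, `COc1cc(C(=O)/C=C/c2cc(-c3cc(OC)c(OC)c(OC)c3)n[nH]2)cc(OC)c1OC`: 5920 nM

In a functional assay on OVCAR-5 cells (Homo sapiens) for inhibition, read by sulforhodamine B assay, with a stated time of 48 h (on this read-out higher numbers stand for lower toxicity in this test and lower numbers for higher toxicity in this test), compound 1 gives 7910 nM, while compound 2 gives 5920 nM. The two numbers lie within the scatter of one another, so compound 1 cannot be separated from compound 2 on this read-out. Compound 3 `COc1cc(-c2cc(/C=C/C(=O)c3ccc(F)c(F)c3)[nH]n2)cc(OC)c1OC` differs from compound 1 by 3,4-difluorophenyl in place of 4-aminophenyl on a carbonyl carbon. Among the compounds with values here, no measured pair shows this change, so no step size is known for it. The step is expected to be a 1.3-fold lower number from compound 1 to compound 3 (0.12 log units; within the scatter), not clearly beyond the scatter. Compound 3 is therefore estimated at 6000 nM, with an expected range from 2000 nM to 20000 nM.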

Compound 3, concentration lethal to 50% of the cells: > 100000 nM
Compound 3 ended at the assay's limit (the forecaster's own chance of this, stated with the estimate: 10%); middle value at least 16-fold (1.22 log units) from the limit.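

In this assay compound 3 gives > 100000 nM, which is a limit of the assay and not a number: the limit of > 100000 nM in this assay, at which 1 of the 3 values shown sits.

The earlier compounds shown here showed no step at this position. Here, 3,4-difluorophenyl in place of 4-aminophenyl on a carbonyl carbon gives an at least 12-fold higher number from compound 1 to compound 3 (1.10 log units; beyond the scatter), so the read-out responds strongly to this exchange, and its full size stays unknown.

The compounds shown leave open whether the departing amine or the entering fluorines carry the step. They also leave open what a single fluorine, an acetamide or a carboxylic acid on that aryl ring would give.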